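The source may hold more compounds than are shown below. What is called first, only, known or untested is meant among the compounds shown, and "the series" means these compounds.

Of the compounds shown here, three built on closely related cores have been tested in a functional assay (aorta) for inhibition, with Rattus norvegicus as the target; a higher number here means a weaker inhibitor, a lower number a stronger inhibitor. Compound 1 `C/N=C(/S)[C@]1(c2cccnc2)CCCC[S@@+]1[O-]` has three entries, 700 nM; 400 nM; > 30000 nM (3 entries). The last of these entries is a limit of the assay and not a number, so compound 1 offers no single figure for comparison. Compound 2 `C/N=C(\S)[C@]1(c2cc(Cl)cc(Cl)c2)CCCC[S+]1[O-]` gives 400 nM. Compound 3 `C/N=C(\S)[C@]1(c2cccc(C#N)c2)CCCC[S+]1[O-]` gives 1600 nM, the higher of the two single numbers, and the gap between them lies beyond the usual scatter. On this evidence, compound 3 is the weaker inhibitor of that pair.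

Compound 4 `C/N=C(\S)[C@]1(c2ccccc2)CCCC[S+]1[O-]` has not yet been measured. It has hydrogen in place of cyano on an aromatic carbon of compound 3: hydrogen in place of cyano on an aromatic carbon. For the measured compounds named here, no measured pair of compounds isolates this change, so the expectation in this assay rests on little. Going by the values given here, the only guide is the spread of the two single numbers, with compound 2 at 400 nM and compound 3 at 1600 nM. A small step toward a higher number seems most likely, and it may not clear the scatter. The expected change is a 1.6-fold higher number from compound 3 to compound 4 (0.19 log units; within the scatter). For compound 4 the estimated value is 2500 nM, with an expected range of 600 nM to 8000 nM.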

Compound 4, concentration for 90% inhibition: 9500 nM
The estimate for compound 4 lay 3.8-fold (0.58 log units) below the measured number; measured number above the stated range.
By their numbers in this assay, from the lowest: compound 2; then compound 3; then compound 4.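

In this assay, replacing the cyano group on the aromatic ring with hydrogen gives a 5.9-fold higher number from compound 3 to compound 4 (0.77 log units; beyond the scatter), so the plain ring of compound 4 is clearly the weaker inhibitor of this pair. For the compounds shown here, this is the first pair here that differs in one place only, and it shows that this position, meta to a large group, is not indifferent to what it carries: potency is lost when the nitrile goes. The data shown do not explain why the nitrile makes this difference.

From the compounds shown here alone, only cyano has been compared directly with hydrogen at this position, so it remains open whether this gain is particular to the nitrile or would also appear with a fluorine atom, a methoxy group or an amide. Compound 2 carries two chlorine atoms on its ring rather than a single substituent, so it does not show how one chlorine atom would compare with either hydrogen or cyano at this position.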